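Sulfamoyl ureas on the shared core: amine to alkoxy swap

A few compounds are considered here, and "the series" means these few. Any claim that something is new, unique, unknown or untested is made for them only; others in the source may bear on it.

Measured so far:
compound 1 `CC(C)NS(=O)(=O)NC(=O)Nc1c(C(C)C)cccc1C(C)C`, an assay on liver for inhibition of sterol O-acyltransferase 1 (Rattus norvegicus), using microsomes (a higher number here means a weaker inhibitor, a lower number a stronger inhibitor), 18000 nM
compound 2 `CCN(CC)S(=O)(=O)NC(=O)Nc1c(C(C)C)cccc1C(C)C`, this assay 2500 nM
compound 3 `CC(C)c1cccc(C(C)C)c1NC(=O)NS(=O)(=O)N1CCCCC1`, this assay 17000 nM

Compound 3 stands second highest of the three numbers; compound 1 is within the scatter of it, while compound 2 sits well lower. Compound 4 `CCCCCCC(C)OS(=O)(=O)NC(=O)Nc1c(C(C)C)cccc1C(C)C` carries the change ((1-methylheptyl)oxy in place of piperidin-1-yl on a sulfonyl sulfur). Going by the values given here, no measured step involves such a group: the known steps are amine swaps on the sulfonyl sulfur, a 7.2-fold lower number from compound 1 to compound 2 (0.86 log units; beyond the scatter), a 1.1-fold lower number from compound 1 to compound 3 (0.02 log units; within the scatter) and a 6.8-fold higher number from compound 2 to compound 3 (0.83 log units; beyond the scatter), so a change here can move the number modestly in either direction. For compound 4 a small step is expected, a 1.5-fold lower number from compound 3 to compound 4 (0.19 log units; within the scatter), and its estimated this assay value is 11000 nM, range 2500 nM to 45000 nM.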

Compound 4, half-maximal inhibitory concentration: 35000 nM
Beside the measured number, compound 4's estimate is 3.2-fold (0.50 log units) below it; low and high end bracket the measured number.
By their numbers in this assay, from the lowest: compound 2; then compounds 3, 1 and 4 (each within the scatter of the next, the first and the last beyond it).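

A (1-methylheptyl)oxy group on the sulfonyl sulfur brings no gain over the amines: replacing piperidin-1-yl gives (a 2.1-fold higher number from compound 3 to compound 4 (0.31 log units; beyond the scatter)), and replacing diethylamino gives (a 14-fold higher number from compound 2 to compound 4 (1.15 log units; beyond the scatter)), the largest step in the set so far. Replacing isopropylamino stays within the scatter (a 1.9-fold higher number from compound 1 to compound 4 (0.29 log units; within the scatter)), so compound 1 and compound 4 cannot be ordered. No evidence at hand accounts for these steps.

Ethoxy and dipropylamino on the sulfonyl sulfur remain open, and with them the question of whether the oxygen link or the chain length sets the number.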